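A few compounds are considered here, and "the series" means these few. Any claim that something is new, unique, unknown or untested is made for them only; others in the source may bear on it.

Three compounds share one core and were tested in a functional assay on HeLa cells (Homo sapiens) for antiproliferative activity, read by MTT assay, with a stated time of 72 h; a lower number here means a stronger inhibitor, a higher number a weaker inhibitor. Compound 1 `COc1cc(C(=O)c2sc3ccccc3c2-c2ccc(Cl)cc2)cc(OC)c1OC` gives 5200 nM, the highest number of the three, although its distances to the others are within the usual scatter. Compound 2 `CCOc1ccc(-c2c(C(=O)c3cc(OC)c(OC)c(OC)c3)sc3ccccc23)cc1` gives 3000 nM, and compound 3 `COc1cc(C(=O)c2sc3ccccc3c2Nc2ccc(Cl)cc2)cc(OC)c1OC` gives 3700 nM. The step of a 1.7-fold lower number from compound 1 to compound 2 (0.24 log units; within the scatter) and the step of a 1.4-fold lower number from compound 1 to compound 3 (0.15 log units; within the scatter) both stay within the scatter, as does a 1.2-fold higher number from compound 2 to compound 3 (0.09 log units; within the scatter).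

Compound 4 `COc1cc(C(=O)c2sc3ccccc3c2Nc2ccc(C)cc2)cc(OC)c1OC` is not yet measured. It differs from compound 1 in one place: (4-methylphenyl)amino in place of 4-chlorophenyl on an aromatic carbon. Within the data shown here, two measured steps bear on this change. The step of a 1.4-fold lower number from compound 1 to compound 3 (0.15 log units; within the scatter) shows what the amino link alone did, and a 1.7-fold lower number from compound 1 to compound 2 (0.24 log units; within the scatter) shows that swapping the group on the outer phenyl ring changed little. Neither moved beyond the scatter, so no step beyond the scatter is expected in this assay either way. Compound 4 is therefore expected to give about 3500 nM, within a range of 1500 nM to 8000 nM, which means an expected step of a 1.5-fold lower number from compound 1 to compound 4 (0.17 log units; within the scatter).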

Compound 4, half-maximal inhibitory concentration: 3500 nM
Compound 4: middle estimate and measured number agree at the digits printed; the measured number falls inside the stated range.
By their numbers in this assay, from the lowest: compounds 2, 4, 3 and 1 (each within the scatter of the next).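

Among these compounds, compound 4 gives the first pair with the same amino link that differs only in one small group: the step of a 1.1-fold lower number from compound 3 to compound 4 (0.02 log units; within the scatter) shows that this exchange makes no clear difference in this assay. The larger changes also stay within the scatter, with a 1.5-fold lower number from compound 1 to compound 4 (0.17 log units; within the scatter) for the change that brings in the amino link's hydrogen-bond donor, and a 1.2-fold higher number from compound 2 to compound 4 (0.07 log units; within the scatter) for the swap from 4-ethoxyphenyl. No measurement shown here explains why these groups read so alike.

The compounds leave open whether any group at this place can move the number beyond the scatter. A carboxylic acid or a longer alkyl chain in place of the methyl, or a morpholine in place of the whole (4-methylphenyl)amino group, would be a further test.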